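This account rests on a few compounds, and the source may have more. Where it says the series, first, only, none or still open, it means among the compounds named here.

In a functional assay on the whole organism for antagonist activity, with Mus musculus as the target (on this read-out lower numbers stand for an effect already at smaller amounts and higher numbers for an effect only at larger amounts of compound), compound 1 `CC(=O)N(C)CC#CCn1ccnc1` gives > 100 mg/kg, which is a limit of the assay. Compound 2 `CC(=O)N(C)CC#CCn1cncc1C` gives 6.6 mg/kg, the lowest number shown, while compound 3 `COC(=O)NCC#CCn1cncc1C` gives 66 mg/kg. Compound 4 `CCOC(=O)N(C)CC#CCn1cncc1C` departs from compound 2 by ethoxy in place of methyl on a carbonyl carbon, with ethoxy in place of methyl on a carbonyl carbon. The change an at least 15-fold lower number from compound 1 to compound 2 (1.18 log units; beyond the scatter) was made at an aromatic carbon and does not bear on this place. The closer precedent is a 10-fold higher number from compound 2 to compound 3 (1.00 log units; beyond the scatter), yet that change also removed the methyl from the amide-type nitrogen, and compound 4 keeps it. Only part of that rise is therefore expected to carry over. The expected change is a 3.0-fold higher number from compound 2 to compound 4 (0.48 log units; beyond the scatter), towards a higher number. For compound 4 the estimated value is 20 mg/kg, with an expected range of 6 mg/kg to 80 mg/kg.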

Compound 4, dose for half-maximal effect: 66 mg/kg
The estimate for compound 4 lay 3.3-fold (0.52 log units) below the measured number, within the range that was stated.
By their numbers in this assay, from the lowest: compound 2; then compounds 3 and 4 (each within the scatter of the next). At a limit, above all of these: compound 1.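

With the methyl on the amide-type nitrogen kept, ethoxy in place of methyl on a carbonyl carbon gives a 10-fold higher number from compound 2 to compound 4 (1.00 log units; beyond the scatter) in this assay. The earlier step, a 10-fold higher number from compound 2 to compound 3 (1.00 log units; beyond the scatter), had also removed that nitrogen methyl, so only now is a rise beyond the scatter seen with the nitrogen unchanged. Nothing shown here gives a reason for this rise.

The compounds shown leave open how an amine or a longer alkoxy chain on this carbonyl carbon would read in this assay. They also leave open whether a methoxy there, with the nitrogen methyl kept, would read like ethoxy.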